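The compounds below may be only part of what the source reports. "The series", "measured", "known", "first", "only" and "open" are said of these compounds alone.

Compound 2 `N#Cc1c(N)nc(SCc2ccn[nH]2)c(C#N)c1-c1ccc(OCC2CC2)cc1` gives 6% in an assay on CHO cells for displacement of a labelled ligand from adenosine receptor A3 (Homo sapiens), read by scintillation counting, with a stated time of 120 min, tested at 1 uM (a lower number here means less inhibition, a higher number more inhibition at the concentration tested (going by the name of the read-out)), the lowest of the two numbers measured; compound 1 `CCOc1ccc(-c2c(C#N)c(N)nc(SCc3ccn[nH]3)c2C#N)cc1` gives 18%. Compound 3 `C=CCOc1ccc(-c2c(C#N)c(N)nc(SCc3ccn[nH]3)c2C#N)cc1` differs from compound 2 by vinyl in place of cyclopropyl on a saturated chain carbon bound to an oxygen on an aromatic ring. Among the compounds with values here, no measured step covers this exchange directly; the only one available, a number 12 percentage points lower from compound 1 to compound 2 (beyond the scatter), concerns the same place but a different pair of groups, so it offers limited guidance. That step was modest, and it removed no ring, whereas the present exchange does. Only a small change is therefore expected, likely within the scatter. Compound 3 is therefore estimated at 11%, between 0% and 25%, a step of a number 5 percentage points higher from compound 2 to compound 3 (within the scatter).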

Compound 3, a percentage reported as inhibition, at one concentration (the size of the read-out at that concentration, not a potency): 13%
Estimate against measurement, compound 3: 2 percentage points below, and the stated range covers the measured number.
By their numbers in this assay, from the lowest: compounds 2, 3 and 1 (each within the scatter of the next, the first and the last beyond it).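

Vinyl in place of cyclopropyl, an exchange that removes a ring, gives a number 7 percentage points higher from compound 2 to compound 3 (within the scatter) in this assay, while vinyl in place of methyl gives a number 5 percentage points lower from compound 1 to compound 3 (within the scatter). Compound 1 and compound 2 lie beyond the scatter of each other, yet compound 3 cannot be separated from either, so the ring is not shown to be needed for the lower number of compound 2. Nothing measured here explains these numbers. Open remains how a longer chain or an amine at this place would read, and whether any group here could lift the number well past that of compound 1.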